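A few compounds are considered here, and "the series" means these few. Any claim that something is new, unique, unknown or untested is made for them only; others in the source may bear on it.

Compound 3 `CN1CCN(c2ccc3nc(-c4cccc5c4OCCO5)c(-c4ccncc4)n3n2)CC1` reaches only a limit in an assay on Sf9 cells for inhibition of receptor-interacting serine/threonine-protein kinase 3 (Homo sapiens), read by luminescence and 33P incorporation, with a stated time of 30 min, in the presence of a further agent that is not named here (a higher number here means a weaker inhibitor, a lower number a stronger inhibitor), giving > 10000 nM. Compound 1 `CN1CCN(c2ccc3nc(-c4ccc(-c5ccccc5)s4)c(-c4ccncc4)n3n2)CC1` likewise shows only a limit, > 10000 nM. The step that the two limits leave unreadable from compound 1 to compound 3 therefore cannot be read, because both values sit at the limit of > 10000 nM in this assay, at which 2 of the 3 values shown sit. Within the data shown here, compound 2 `CN1CCN(c2ccc3nc(-c4cccc(-c5ccccc5)c4)c(-c4ccncc4)n3n2)CC1` is the one member with a number, giving 450 nM in this assay. Compound 4 `CN1CCN(c2ccc3nc(-c4cccc(-c5ccsc5)c4)c(-c4ccncc4)n3n2)CC1` arises from compound 3 by 3-(thiophen-3-yl)phenyl in place of 2,3-dihydro-1,4-benzodioxin-5-yl on an aromatic carbon. Among the measured compounds shown here, no measured step spans this change; compound 2 is the nearest measured case and the only guide available. Compound 4 is expected to move toward compound 2, by an estimated at least 20-fold lower number from compound 3 to compound 4 (1.30 log units; beyond the scatter). Compound 4 is therefore expected to give about 500 nM in this assay, within 200 nM to 2000 nM.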

Compound 4, half-maximal inhibitory concentration: 300 nM
Estimate against measurement, compound 4: 1.7-fold (0.22 log units) above; the range from low to high includes it.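

In this assay, the result shows that this position tolerates more than one ring on the phenyl group: thiophen-3-yl and phenyl cannot be told apart, with a 1.5-fold lower number from compound 2 to compound 4 (0.18 log units; within the scatter). Compound 4 also gives a second case in which a 3-substituted phenyl group reads as a number, with an at least 33-fold lower number from compound 3 to compound 4 (1.52 log units; beyond the scatter) and an at least 33-fold lower number from compound 1 to compound 4 (1.52 log units; beyond the scatter), though both sizes are bounded only by a limit: the limit of > 10000 nM in this assay, at which 2 of the 4 values shown sit.

The compounds shown leave open whether an aminomethyl group or a carboxylic acid in place of the thiophen-3-yl would hold this level.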